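Thiophen-2-yl to phenyl at the low end

This account rests on a few compounds, and the source may have more. Where it says the series, first, only, none or still open, it means among the compounds named here.

Within the data shown here, in an ADME assay on Caco-2 cells (Homo sapiens) for permeability, in the apical to basolateral direction, tested at 10 uM (a lower number here means that the compound crosses the layer more slowly, a higher number that the compound crosses the layer faster), compound 2 (`CC(C)CCn1nc(-c2cccs2)c(O)c(C2=CS(=O)(=O)c3cc(NS(C)(=O)=O)ccc3N2)c1=O`) gives 0.012 10^-6 cm/s and holds the lower of the two numbers so far, while compound 1 (`CC(C)CCn1nc(-c2cccs2)c(O)c(C2=NS(=O)(=O)c3cc(N(C)S(C)(=O)=O)ccc3N2)c1=O`) gives 0.2 10^-6 cm/s and stands well beyond the scatter above it. Compound 3 (`CC(C)CCn1nc(-c2ccccc2)c(O)c(C2=CS(=O)(=O)c3cc(NS(C)(=O)=O)ccc3N2)c1=O`) carries phenyl in place of thiophen-2-yl on an aromatic carbon. Among the measured compounds shown here, no measured pair shows this change, so in this assay no step beyond the scatter is expected. The expected move (a 1.3-fold higher number from compound 2 to compound 3 (0.10 log units; within the scatter)) is small and slightly upward. Compound 3 is estimated at 0.015 10^-6 cm/s (range 0.005 10^-6 cm/s to 0.05 10^-6 cm/s).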

Compound 3, apparent permeability: 0.019 10^-6 cm/s
Compound 3: the middle estimate sits 1.3-fold (0.10 log units) below what was measured; low and high end bracket the measured number.
By their numbers in this assay, from the lowest: compounds 2 and 3 (each within the scatter of the next); then compound 1.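

In this assay, phenyl in place of thiophen-2-yl on this aromatic carbon gives a 1.6-fold higher number from compound 2 to compound 3 (0.20 log units; within the scatter). The ring sulfur can thus be exchanged for a six-membered aromatic ring of carbon only, and the two numbers still lie within the scatter of each other at the low end of the series. No measurement at hand bears on this result. Open remains what a pyridyl ring, a cyclohexyl ring or an amine on the phenyl would give at this carbon. Also open, from the compounds shown here alone, is whether the same exchange reads alike on the core of compound 1.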